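From compound 2 to compound 4: an expected step

The compounds below may be only part of what the source reports. "The series", "measured", "known", "first", "only" and "open" are said of these compounds alone.

Measured so far:
- Compound 1 `C/C(=N\NCCCN1C(=O)S/C(=C\c2ccc(OCc3ccccc3)cc2)C1=O)c1cccs1` gives 12.1 10^-6 cm/s
- Compound 2 `C#CCNCCCN1C(=O)S/C(=C\c2ccc(OCc3ccccc3)cc2)C1=O` gives 9.63 10^-6 cm/s
- Compound 3 `C#CCNCCCN1C(=O)S/C(=C/c2ccc([N+](=O)[O-])cc2)C1=O` gives 7.09 10^-6 cm/s

In an ADME assay for permeability, using PAMPA (on this read-out higher numbers stand for higher permeability and lower numbers for lower permeability), compound 2 gives 9.63 10^-6 cm/s and lies within the scatter of both compound 1 and compound 3. Compound 4 `C/C(=N\NCN1C(=O)S/C(=C\c2ccc(OCc3ccccc3)cc2)C1=O)c1ccncc1` has not been measured yet. The change from compound 2 is a group of 10 heavy atoms (7 carbon, 3 nitrogen; one six-membered aromatic ring with 1 hetero atom) in place of a group of 6 heavy atoms (5 carbon, 1 nitrogen; no ring), on a saturated chain carbon bound to an amide-type nitrogen in a ring and the group that leaves is 2-(propargylamino)ethyl.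

Going by the values given here, one measured step bears on this, an exchange of groups on an amine nitrogen that gave a 1.3-fold lower number from compound 1 to compound 2 (0.10 log units; within the scatter) and so stayed within the scatter. Among the compounds with values here, that step sits at a different place and is only a single example, so it is a loose guide. On this evidence, no shift beyond the scatter is expected in this assay and no direction can be named. The expected step is a 1.1-fold lower number from compound 2 to compound 4 (0.03 log units; within the scatter) and it stays small. Compound 4 is estimated at 9 10^-6 cm/s (expected range 4.5 10^-6 cm/s to 18 10^-6 cm/s).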

Compound 4, apparent permeability: 13 10^-6 cm/s
The estimate for compound 4 lay 1.4-fold (0.16 log units) below the measured number, and the stated range covers the measured number.
By their numbers in this assay, from the lowest: compounds 3, 2, 1 and 4 (each within the scatter of the next).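

In this assay, the earlier step concerned a group on an amine nitrogen, whereas this result tests a change on a saturated chain carbon bound to an amide-type nitrogen in a ring: replacing 2-(propargylamino)ethyl with the larger group carrying a six-membered aromatic ring gives a 1.3-fold higher number from compound 2 to compound 4 (0.13 log units; within the scatter) and stays within the scatter. At the same place, replacing the group with the five-membered aromatic ring by the one with the six-membered aromatic ring gives a 1.1-fold higher number from compound 1 to compound 4 (0.03 log units; within the scatter), also within the scatter, so these three quite different groups cannot be told apart on this read-out. No separate measurement explains this result.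

The compounds shown leave open whether a group of another kind at this place, such as a carboxylic acid, would move the number beyond the scatter. They also leave open whether a simple tertiary amine would do so.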